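This account rests on a few compounds, and the source may have more. Where it says the series, first, only, none or still open, it means among the compounds named here.

Measured compounds in an assay on HEK cells for antagonist activity at transient receptor potential cation channel subfamily V member 1 (Homo sapiens), read by FLIPR; on this read-out lower numbers stand for stronger inhibition and higher numbers for weaker inhibition:
compound 1 `O=C(NCc1ccc(C(F)(F)F)nc1N1CCC(Cc2ccccc2)CC1)Nc1cccc2[nH]c(=O)ccc12`, 1.59 nM
compound 2 `O=C(NCc1ccc(C(F)(F)F)nc1N1CCCC1)Nc1cccc2[nH]c(=O)ccc12`, 0.94 nM
compound 3 `CCCCCOc1nc(C(F)(F)F)ccc1CNC(=O)Nc1cccc2[nH]c(=O)ccc12`, 2.72 nM

Of the three numbers in this assay the largest belongs to compound 3. Compound 1 lies within the scatter of it, so the two cannot be told apart; only compound 2 is separated from compound 3, through a 2.9-fold higher number from compound 2 to compound 3 (0.46 log units; beyond the scatter), a modest rise on moving from pyrrolidin-1-yl to pentyloxy.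

Compound 4 `CC1CCC(c2nc(C(F)(F)F)ccc2CNC(=O)Nc2cccc3[nH]c(=O)ccc23)CC1` differs from compound 3 by 4-methylcyclohexyl in place of pentyloxy on an aromatic carbon. Going by the values given here, the one measured step at this position, a 2.9-fold higher number from compound 2 to compound 3 (0.46 log units; beyond the scatter), shows that exchanging one group for another of different shape at this carbon changes the number only modestly; no measured step introduces a carbon-only ring there, so the direction is not fixed by the data. All three measured numbers sit close together, which suggests the position tolerates varied groups. For compound 4 the expected step is therefore small, a 1.1-fold lower number from compound 3 to compound 4 (0.04 log units; within the scatter), and not clearly beyond the scatter. Compound 4 is estimated at 2.5 nM in this assay, with a range of 0.8 nM to 8 nM.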

Compound 4, half-maximal inhibitory concentration: 1.44 nM
Estimate against measurement, compound 4: 1.7-fold (0.24 log units) above; low and high end bracket the measured number.
By their numbers in this assay, from the lowest: compounds 2, 4, 1 and 3 (each within the scatter of the next, the first and the last beyond it).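

In this assay, 4-methylcyclohexyl in place of pentyloxy gives a step within the scatter (a 1.9-fold lower number from compound 3 to compound 4 (0.28 log units; within the scatter)), and the same holds for 4-methylcyclohexyl in place of pyrrolidin-1-yl (a 1.5-fold higher number from compound 2 to compound 4 (0.19 log units; within the scatter)). Going by these compounds alone, this carbon therefore also accepts a ring of carbon only, with no hydrogen-bond acceptor in the group, and the number cannot be told apart from those of compound 2 and compound 3, the only pair still separated beyond the scatter. No measurement is at hand that would explain this tolerance.

On these data alone, whether the tolerance extends to a phenyl ring, a carboxylic acid or a primary amine on this carbon stays open. Also open, as far as these compounds go, is whether cyclohexyl without the methyl group would fall within the same narrow spread.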